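Where Compound 4 Might Land on Clearance

A few compounds are considered here, and "the series" means these few. Any claim that something is new, unique, unknown or untested is made for them only; others in the source may bear on it.

Results so far in an ADME assay on microsomes from liver (Rattus norvegicus) for metabolic stability, read by HPLC, using NADPH, with stated times of 5 min and 60 min, tested at 10 uM (a higher number here means faster removal of the compound, a lower number slower removal), for three compounds
Compound 1 `Cn1cc(-c2cc(C(N)=O)ccc2Oc2ccccc2)c2cc[nH]c2c1=O` gives 550 mL/min/kg
Compound 2 `CCS(=O)(=O)Nc1ccc(Oc2ccc(C#N)cc2)c(-c2cn(C)c(=O)c3[nH]ccc23)c1` gives 81.7 mL/min/kg
Compound 3 `Cn1cc(-c2cc(NS(C)(=O)=O)ccc2Oc2cccnc2)c2cc[nH]c2c1=O` gives 350 mL/min/kg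

Compound 2 has the lowest number of the three. Compound 3 is its nearest neighbour and compound 1 lies furthest away, and both gaps are beyond the usual scatter of repeated measurements.

Compound 4 `CCS(=O)(=O)Nc1ccc(OC2CCC(N(C)C)CC2)c(-c2cn(C)c(=O)c3[nH]ccc23)c1` has not yet been measured. It differs from compound 2 in one place only: 4-(dimethylamino)cyclohexyl in place of 4-cyanophenyl on an oxygen on an aromatic ring (in words, 4-(dimethylamino)cyclohexyl in place of 4-cyanophenyl on an oxygen on an aromatic ring).

Within the data shown here, no two measured compounds differ in just one place, and the data offer no direct guide to this change. Only the spread of the values can help, and three numbers make a thin basis. Compound 2 (81.7 mL/min/kg) sits at the low end, while compound 3 (350 mL/min/kg) and compound 1 (550 mL/min/kg) both stand well above it. A new group is thus expected to move the number up rather than down. The expected step, of moderate size and uncertain, is a 2.2-fold higher number from compound 2 to compound 4 (0.34 log units; beyond the scatter) in this assay (an upward move). Compound 4 is estimated at 180 mL/min/kg in this assay (expected range 60 mL/min/kg to 500 mL/min/kg).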

Compound 4, clearance: < 45 mL/min/kg
Compound 4: a limit, no number; the forecaster's own chance of this, stated with the estimate: 5%; at least 4.0-fold (0.60 log units) between middle value and limit.
By their numbers in this assay, from the lowest: compound 2; then compounds 3 and 1 (each within the scatter of the next). At a limit, below all of these: compound 4.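

The change from 4-cyanophenyl to 4-(dimethylamino)cyclohexyl shows that the group on this oxygen need not be aromatic for the number to stay low: in this assay, compound 4 gives < 45 mL/min/kg, which is a limit of the assay and not a number. The change gives an at least 1.8-fold lower number from compound 2 to compound 4 (0.25 log units; that floor lies within the scatter), so the number did not rise, though the true size of the fall stays unknown and a fall larger than the scatter is not shown. Among the compounds shown, only compound 4 stands at such a limit: the limit of < 45 mL/min/kg in this assay, at which 1 of the 4 values shown sits.

The compounds shown leave open which part of the new group goes with this result, since the non-aromatic ring and the dimethylamino group enter together in a single change. A plain cyclohexyl on the same oxygen would speak to the ring without the amine, and a 4-(dimethylamino)phenyl would speak to the amine on an aromatic ring, while an exact number for compound 4 would still be needed to size the step.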